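The compounds below may be only part of what the source reports. "The series", "measured", "known", "first", "only" and "open" are said of these compounds alone.

Within the data shown here, in an ADME assay on MT4 cells (Homo sapiens) for cytotoxicity, read by MTT assay (on this read-out lower numbers stand for higher toxicity in this test and higher numbers for lower toxicity in this test), compound 1 (`O=C1c2ccccc2C(=O)N1CCOC(=S)N(C(=O)c1ccccc1[N+](=O)[O-])c1ccc(Cl)cc1`) gives 21000 nM and compound 2 (`O=C1c2ccccc2C(=O)N1CCOC(=S)N(C(=O)c1cc(F)ccc1F)c1ccc(Cl)cc1`) gives 54000 nM, the higher of the two numbers so far. Compound 3 (`O=C1c2ccccc2C(=O)N1CCOC(=S)N(C(=O)c1c(F)cccc1F)c1ccc(Cl)cc1`) differs from compound 2 as follows: 2,6-difluorophenyl in place of 2,5-difluorophenyl on a carbonyl carbon. In short, 2,6-difluorophenyl stands in place of 2,5-difluorophenyl on a carbonyl carbon. Among the measured compounds shown here, the only measured step at this place is a 2.6-fold higher number from compound 1 to compound 2 (0.41 log units; beyond the scatter), which replaced 2-nitrophenyl with 2,5-difluorophenyl. For the measured compounds named here, it bears only loosely on the new change, since no measured pair compares two difluorophenyl groups. With the same atoms joined differently, a change smaller than a 2.6-fold higher number from compound 1 to compound 2 (0.41 log units; beyond the scatter) is expected in this assay, most likely none beyond the scatter and with no firm direction. The expected step is a 1.1-fold lower number from compound 2 to compound 3 (0.05 log units; within the scatter). Compound 3 is estimated at 48000 nM, with an expected range of 22000 nM to 100000 nM.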

Compound 3, half-maximal cytotoxic concentration: 39000 nM
Compound 3: middle estimate off by 1.2-fold (0.09 log units), on the high side; measured number inside the range.
By their numbers in this assay, from the lowest: compounds 1, 3 and 2 (each within the scatter of the next, the first and the last beyond it).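

In this assay the swap of 2,5-difluorophenyl for 2,6-difluorophenyl on a carbonyl carbon gives a 1.4-fold lower number from compound 2 to compound 3 (0.14 log units; within the scatter) and so does not separate these two groups, which have the same atoms joined differently. The step against the nitro compound is a 1.9-fold higher number from compound 1 to compound 3 (0.27 log units; within the scatter) and is also within the scatter, which leaves compound 3 unresolved from both neighbours, even though compound 1 and compound 2 are resolved from each other by a 2.6-fold higher number from compound 1 to compound 2 (0.41 log units; beyond the scatter) in this assay. Among these compounds, at this position the one step beyond the scatter is therefore small, and compound 3 does not show that difluorophenyl groups as a class differ from 2-nitrophenyl.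

Open, going by these compounds, is whether an unsubstituted phenyl, an aminophenyl or a carboxylic acid at this place would shift the number beyond the scatter. The data carry no information that explains any of these numbers.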